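Cytotoxicity limit in the benzyl series: phenyl to hydrogen

A few compounds are considered here, and "the series" means these few. Any claim that something is new, unique, unknown or untested is made for them only; others in the source may bear on it.

In an ADME assay on HepG2 cells (Homo sapiens) for cytotoxicity, in the presence of a further agent that is not named here (a higher number here means a weaker inhibitor, a lower number a stronger inhibitor), compound 1 `Cn1c(Cc2ccccc2)nc(C(=O)NCc2ccccc2)c(O)c1=O` gives > 100000 nM, which is a limit of the assay and not a number. Compound 2 `Cn1c(Cc2ccccc2C(F)(F)F)nc(C(=O)NCC2CCCCC2)c(O)c1=O` gives > 100000 nM, which is also a limit. Compound 1 therefore has no exact place in the series, and the only available reference point is the limit of > 100000 nM in this assay, at which 2 of the 2 values shown sit.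

Compound 3 `Cc1nc(C(=O)NCc2ccccc2)c(O)c(=O)n1C` comes from compound 1 through hydrogen in place of phenyl on a saturated chain carbon bound to an aromatic carbon, which also reads as benzyl to methyl. Going by the values given here, no measured step gives a size for this change. No shift beyond the usual scatter is expected in this assay, and no direction can be favoured. The expectation rests on compound 1, whose reading of > 100000 nM is a limit. A reported limit rather than a number is the likely outcome for the new compound. The estimated change is a number no higher from compound 1 to compound 3 (the limit leaves the size open). For compound 3 the estimated value is 100000 nM, with an expected range from 50000 nM to 200000 nM.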

Compound 3, half-maximal inhibitory concentration: > 100000 nM
Compound 3 gave a limit, no number; the forecaster's own chance of this, stated with the estimate: 85%; the middle value sits exactly at the limit.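

Compound 3 and compound 1 both return a limit and not a number in this assay, so no step can be read for the change from benzyl to methyl. The compounds shown leave open how strongly any of them inhibits, and whether any change in the series shifts the read-out, with all values resting on one reference point: the limit of > 100000 nM in this assay, at which 3 of the 3 values shown sit.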